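Removing a Trifluoromethyl Group from a Urotensin Receptor Agonist

The source may report more compounds than this note shows. Statements on the series, on what has been measured and on what is new or still open speak of the compounds shown alone.

Of the compounds shown here, two have been measured so far. Compound 2 `CN(C)CCC(NC(=O)/C=C/c1ccc(C(F)(F)F)cc1)c1ccc2ccccc2c1` is the stronger of the pair: in a functional assay on NIH3T3 cells for agonist activity at Urotensin-2 receptor (Homo sapiens), with a stated time of 5 days (on this read-out lower numbers stand for an effect already at smaller amounts and higher numbers for an effect only at larger amounts of compound), compound 2 gives 135 nM, the lowest of the two numbers in hand. Compound 1 `Cc1ccc(C(CCN(C)C)NC(=O)C#Cc2ccccc2)cc1` gives 3090 nM in this assay, a gap beyond the usual scatter, but the two structures differ in several places at once, so no single change can be credited.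

Compound 3 `CN(C)CCC(NC(=O)/C=C/c1ccccc1)c1ccc2ccccc2c1` has not yet been measured. It differs from compound 2 in one place only: hydrogen in place of trifluoromethyl on an aromatic carbon. Going by the values given here, no measured pair shows this exact change, so the expectation rests on compound 2 alone. A modest weakening seems the most likely outcome, although an unchanged number within the scatter cannot be excluded. Compound 3 is therefore expected to give about 400 nM in this assay, somewhere between 130 nM and 1500 nM. That expectation amounts to a step of a 3.0-fold higher number from compound 2 to compound 3 (0.47 log units; beyond the scatter).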

Compound 3, half-maximal effective concentration: 589 nM
The estimate for compound 3 lay 1.5-fold (0.17 log units) below the measured number; measured number inside the range.
By their numbers in this assay, from the lowest: compound 2; then compound 3; then compound 1.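

In this assay, going by these compounds alone, replacing trifluoromethyl with hydrogen on the aromatic carbon para to a large group gives a 4.4-fold higher number from compound 2 to compound 3 (0.64 log units; beyond the scatter), the first change here that can be credited to a single place. This step shows that the group at this position affects the read-out: 4-(trifluoromethyl)phenyl gives a lower number than phenyl on otherwise identical structures. No separate measurement bears on the reason for this difference.

The compounds shown leave open whether it is trifluoromethyl in particular that matters, or whether a chlorine atom, a methoxy group or a nitrile at the same place would give a similar number. As far as these compounds go, with a single pair, it also remains open whether the same exchange would give a similar step on a different core.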